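This account rests on a few compounds, and the source may have more. Where it says the series, first, only, none or still open, it means among the compounds named here.

Compound 1 `Cc1ccccc1Nc1nc(Nc2cccnc2)ncc1Cl` gives 56500 nM in a functional assay on MCF7 cells (Homo sapiens) for inhibition, read by CCK-8 assay, with a stated time of 48 h; on this read-out higher numbers stand for weaker inhibition of growth and lower numbers for stronger inhibition of growth.
Compound 2 `Cc1ccccc1Nc1nc(NCc2ccncc2)ncc1Cl` gives only a limit of the assay, > 100000 nM.
Compound 3 `COc1cccc(CNc2nc(Nc3ccc(N4CCN(C)CC4)cn3)ncc2Cl)c1` gives 19500 nM.

Of the two numbers, compound 3 stands lowest, with compound 1 above it beyond the scatter; the value for compound 2 is a limit, (the limit of > 100000 nM in this assay, at which 1 of the 3 values shown sits).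

Compound 4 `Cc1cc(C)c(Nc2nc(Nc3ccc(N4CCN(C)CC4)cn3)ncc2Cl)c(C)c1` differs from compound 3 by 2,4,6-trimethylphenyl in place of 3-methoxybenzyl on a nitrogen on an aromatic ring. Among the measured compounds shown here, the one measured step, an at least 1.7-fold higher number from compound 1 to compound 2 (0.24 log units; that floor lies within the scatter), touches the same nitrogen in the reverse sense: a ring hung on a methylene replaced a ring bound directly, and the number rose. Reading that backwards, the expected step is a modest fall, a 2.2-fold lower number from compound 3 to compound 4 (0.34 log units; beyond the scatter), though with only one step to lean on the uncertainty is wide. Compound 4 is therefore estimated at 9000 nM, between 2500 nM and 40000 nM.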

Compound 4, concentration for 50% growth inhibition: 9470 nM
Estimate against measurement, compound 4: 1.1-fold (0.02 log units) below, within the range that was stated.
By their numbers in this assay, from the lowest: compound 4; then compound 3; then compound 1. At a limit, above all of these: compound 2.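

In this assay, this nitrogen gives a step with real numbers at both ends, not a limit: a 2.1-fold lower number from compound 3 to compound 4 (0.31 log units; beyond the scatter). The swap keeps the count of heavy atoms the same, yet it removes the methylene link and the methoxy group and adds the methyl groups all at once, so the step belongs to the whole change. Nothing measured here accounts for the step.

The compounds shown leave open which of these parts carries it. A plain benzyl or plain phenyl on this nitrogen would begin to separate them.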